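Cytotoxicity Outlook for a Carboxymethylphenyl Analogue

A few compounds are considered here, and "the series" means these few. Any claim that something is new, unique, unknown or untested is made for them only; others in the source may bear on it.

Measured compounds:
compound 1 `CCOC(=O)CCCCCOc1cccc(CN(C(=O)c2ccc(-c3ccc(C(C)=O)s3)cc2)C(C)C)c1` — > 26000 nM
compound 2 `CCOC(=O)CCCCCOc1cccc(CN(C(=O)c2ccc(-c3cn(S(=O)(=O)c4ccccc4)c4ccccc34)cc2)C(C)C)c1` — > 26000 nM

In an ADME assay on BJ cells (Homo sapiens) for cytotoxicity, read by CellTiter-Glo and resazurin assay, with a stated time of 72 h (a higher number here means that more compound is needed for the effect, a lower number that less compound is needed), compound 1 gives > 26000 nM, which is a limit of the assay rather than a number. Compound 2 in this assay gives > 26000 nM, again a limit. Both results sit at the limit of > 26000 nM in this assay, at which 2 of the 2 values shown sit, so compound 1 cannot be placed above or below any other compound within the measured set. The untested compound 3 `CCOC(=O)CCCCCOc1cccc(CN(C(=O)c2ccc(-c3cccc(CC(=O)O)c3)cc2)C(C)C)c1` differs from compound 1 by 3-(carboxymethyl)phenyl in place of 5-acetylthiophen-2-yl on an aromatic carbon. Within the data shown here, no step between measured compounds is available to gauge what this change does in this assay. The expectation for compound 3 is for no step beyond the usual scatter, a step that the limit leaves unreadable from compound 1 to compound 3, because compound 1 already rests at the limit of > 26000 nM in this assay, at which 2 of the 2 values shown sit. Compound 3 is therefore estimated at 30000 nM in this assay, within a range from 15000 nM to 80000 nM, with a strong chance that the assay once more returns only a limit.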

Compound 3, half-maximal effective concentration: > 26000 nM
Compound 3 was reported as a limit; the forecaster's own chance of this, stated with the estimate: 85%; the middle value does not contradict the limit.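

No step can be read between compound 1 and compound 3, since each result in this assay is a limit and not a number: the limit of > 26000 nM in this assay, at which 3 of the 3 values shown sit.

The compounds shown leave open whether 3-(carboxymethyl)phenyl in place of 5-acetylthiophen-2-yl shifts the half-maximal effective concentration at all.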